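Methoxy in Place of Trifluoromethyl on the Aryl Ring

This account rests on a few compounds, and the source may have more. Where it says the series, first, only, none or still open, it means among the compounds named here.

Three measured compounds share one core. In a functional assay on CHO-K1 cells for antagonist activity at metabotropic glutamate receptor 5 (Homo sapiens), read by calcium flux (on this read-out lower numbers stand for stronger inhibition and higher numbers for weaker inhibition), compound 1 `Cc1cnnc(C#Cc2ccccc2)n1` gives 140 nM. Compound 2 `Cc1cnnc(C#Cc2cccc(Cl)c2)n1` gives 4.2 nM in this assay, and compound 3 `Cc1cnnc(C#Cc2cccc(C(F)(F)F)c2)n1` gives 85 nM there. Compound 3 thus stands second highest of the three numbers: it sits close to compound 1, the step of a 1.6-fold lower number from compound 1 to compound 3 (0.22 log units; within the scatter) lying within the scatter, and far from compound 2, as the step of a 20-fold higher number from compound 2 to compound 3 (1.31 log units; beyond the scatter) shows.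

Compound 4 `COc1cccc(C#Cc2nncc(C)n2)c1` differs from compound 3 by methoxy in place of trifluoromethyl on an aromatic carbon. Within the data shown here, no measured step exchanges these two groups. Among the measured compounds shown here, the steps that bear on it are those at the same place: a 33-fold lower number from compound 1 to compound 2 (1.52 log units; beyond the scatter), a 1.6-fold lower number from compound 1 to compound 3 (0.22 log units; within the scatter) and a 20-fold higher number from compound 2 to compound 3 (1.31 log units; beyond the scatter). Together they show that the group at this position can move the number widely, with chloro giving the largest gain. In this assay compound 4 is therefore expected to give a lower number than compound 3, with an estimated step of a 2.8-fold lower number from compound 3 to compound 4 (0.45 log units; beyond the scatter), though the size is uncertain. Compound 4 is estimated at 30 nM, with a range from 5 nM to 150 nM.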

Compound 4, half-maximal inhibitory concentration: 312 nM
Beside the measured number, compound 4's estimate is 10-fold (1.02 log units) below it; measured number outside the range, above it.
By their numbers in this assay, from the lowest: compound 2; then compounds 3 and 1 (each within the scatter of the next); then compound 4.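

In this assay, methoxy is the only group shown at this place that raises the number from the hydrogen of the core, with a 2.2-fold higher number from compound 1 to compound 4 (0.35 log units; beyond the scatter). Exchanging trifluoromethyl for methoxy also raises it, with a 3.7-fold higher number from compound 3 to compound 4 (0.56 log units; beyond the scatter), and exchanging chloro for methoxy gives the widest step in the series, a 74-fold higher number from compound 2 to compound 4 (1.87 log units; beyond the scatter). The position can therefore move the number in both directions from hydrogen, down with chloro and up with methoxy, while trifluoromethyl stays within the scatter of hydrogen.

The compounds shown leave open how a bromine atom, a nitrile or an amine would read at this same place, and whether methoxy would give a similar result on another carbon of the ring. No measurement offered here accounts for the gap between methoxy and chloro.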